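Cytotoxicity notes on the aryl amide series, compound 2 to 3

A few compounds are considered here, and "the series" means these few. Any claim that something is new, unique, unknown or untested is made for them only; others in the source may bear on it.

Measured so far:
compound 1 `O=C(Nc1ncc(Cc2ccc(F)cc2)s1)c1ccc(Cl)cc1Cl` — > 50000 nM
compound 2 `O=C(Nc1ncc(C(Oc2ccc3cc(Br)ccc3c2)c2ccc(Cl)cc2)s1)c1cccs1` — "not toxic" (no number reported)

In an ADME assay on HepG2 2.2.15 cells (Homo sapiens) for cytotoxicity (on this read-out higher numbers stand for lower toxicity in this test and lower numbers for higher toxicity in this test), compound 1 returns only a limit of the assay, > 50000 nM. In this assay compound 2 is reported simply as "not toxic" (no number reported), with no number attached. Going by the values given here, compound 2 thus stands on no single value of its own; the one further value in the set is a limit, namely (the limit of > 50000 nM in this assay, at which 1 of the 2 values shown sits), so both measured compounds sit at or beyond the top of what this assay resolves.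

Compound 3 `Cc1noc(C)c1C(=O)Nc1ncc(C(Oc2ccc3cc(Br)ccc3c2)c2ccc(Cl)cc2)s1` has not yet been run in this assay. It differs from compound 2 at the carbonyl carbon bearing the amide-type nitrogen: 3,5-dimethyl-1,2-oxazol-4-yl in place of thiophen-2-yl on a carbonyl carbon. Among the compounds with values here, no step between measured compounds exists to size this change, and the two measured compounds give nothing but a limit and a qualitative call. The working expectation in this assay is therefore no shift beyond the usual scatter, in neither direction. Compound 3 is estimated at 50000 nM in this assay, with a range of 20000 nM to 100000 nM, and most probably only a limit will again be reported.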

Compound 3, half-maximal cytotoxic concentration: "not toxic" (no number reported)
Compound 3: no number reported; the estimate stays without a comparison.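

Compound 2 and compound 3 are both reported in this assay as "not toxic" with no number attached, so no step can be read between them. Whether thiophen-2-yl and 3,5-dimethyl-1,2-oxazol-4-yl differ at all in half-maximal cytotoxic concentration stays open, and the only figure in the set is a limit: the limit of > 50000 nM in this assay, at which 1 of the 3 values shown sits.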